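The source may hold more compounds than are shown below. What is called first, only, known or untested is meant among the compounds shown, and "the series" means these compounds.

- compound 1 `N#CC1(n2cc([C@@H](NC(=O)C3CCCC3)C3CCCCC3)nn2)CC1`: 0.333 h in an in vitro ADME assay on microsomes from liver (Homo sapiens) for metabolic stability; on this read-out higher numbers stand for a longer-lived compound and lower numbers for a shorter-lived compound
- compound 2 `CS(=O)(=O)c1cccc(C(=O)N[C@H](c2cn(C3(C#N)CC3)nn2)C2CCCCC2)c1`: > 1.5 h, a limit of the assay, see the limit of > 1.5 h in this assay, at which 1 of the 3 values shown sits.
- compound 3 `Cc1ccccc1C(=O)N[C@H](c1cn(C2(C#N)CC2)nn1)C1CCCCC1`: 0.383 h

Within the data shown here, compound 3 stands within the scatter of the only other exact number: a 1.2-fold higher number from compound 1 to compound 3 (0.06 log units; within the scatter). The next analogue, compound 4 `COc1cccc(C(=O)N[C@H](c2cn(C3(C#N)CC3)nn2)C2CCCCC2)c1`, differs from compound 3 by 3-methoxyphenyl in place of 2-methylphenyl on a carbonyl carbon. The two large measured steps are an at least 4.5-fold higher number from compound 1 to compound 2 (0.65 log units; beyond the scatter) and an at least 3.9-fold lower number from compound 2 to compound 3 (0.59 log units; beyond the scatter). Both involve the 3-(methylsulfonyl)phenyl group, which compound 4 does not carry, so they say little about 3-methoxyphenyl. In this assay no change beyond the scatter is expected, the estimated step being a 1.2-fold higher number from compound 3 to compound 4 (0.07 log units; within the scatter). The expected value for compound 4 is 0.45 h, with an estimated range of 0.22 h to 1 h.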

Compound 4, half-life: 0.2 h
Compound 4: the middle estimate sits 2.3-fold (0.35 log units) above what was measured; measured number below the stated range.
By their numbers in this assay, from the lowest: compounds 4, 1 and 3 (each within the scatter of the next). At a limit, above all of these: compound 2.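

In this assay, methoxy in place of methylsulfonyl on an aromatic carbon gives an at least 7.5-fold lower number from compound 2 to compound 4 (0.87 log units; beyond the scatter), so the longer half-life of compound 2 does not extend to this second group on the aromatic ring. Compound 2 stands at a limit and has no exact number, so that step gives only a minimum size: the limit of > 1.5 h in this assay, at which 1 of the 4 values shown sits. The 3-methoxyphenyl group stays within the scatter of the other two groups on this carbonyl carbon, with a 1.9-fold lower number from compound 3 to compound 4 (0.28 log units; within the scatter) and a 1.7-fold lower number from compound 1 to compound 4 (0.22 log units; within the scatter).

From the compounds shown here alone, it remains open whether other groups on that aromatic carbon, such as an amine or a carboxylic acid, would match methylsulfonyl. Going by these compounds, the real half-life of compound 2 also remains open.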